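The compounds below may be only part of what the source reports. "The series", "measured", "known", "first", "only" and "open" are said of these compounds alone.

Measured compounds:
compound 1 `O=c1cc(I)n([C@@H]2O[C@H](COP(=O)(O)OP(=O)(O)O)[C@@H](O)[C@H]2O)c(=O)[nH]1` with 15 nM
compound 2 `O=c1nc(SCc2ccccc2)ccn1[C@@H]1O[C@H](COP(=O)(O)OP(=O)(O)O)[C@@H](O)[C@H]1O` with 800 nM
compound 3 `O=c1ccn([C@]23CC2[C@H](COP(=O)(O)OP(=O)(O)O)[C@@H](O)C3)c(=O)[nH]1` with 230 nM

In an in vitro functional assay on 1321-N1 cells for agonist activity at P2Y purinoceptor 6 (Homo sapiens) (on this read-out higher numbers stand for an effect only at larger amounts of compound and lower numbers for an effect already at smaller amounts), compound 2 shows the highest of the three numbers; compound 3 sits nearer to it, and compound 1 gives the lowest number of the group. The unmeasured compound 4 `O=C(O)CSc1ccn([C@@H]2O[C@H](COP(=O)(O)OP(=O)(O)O)[C@@H](O)[C@H]2O)c(=O)n1` differs from compound 2 in one place: carboxy in place of phenyl on a saturated chain carbon bound to a sulfur. For the measured compounds named here, no pair of measured compounds shares this change, so the direction of the step is not anchored by any measured step here. Compound 4 is expected to stay close to compound 2, with the step from compound 2 to compound 4 estimated as a 1.5-fold higher number from compound 2 to compound 4 (0.18 log units; within the scatter), leaning slightly toward a higher number but possibly within the scatter. For compound 4 the estimate in this assay is 1200 nM, within 300 nM to 5000 nM.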

Compound 4, half-maximal effective concentration: 1700 nM
Estimate against measurement, compound 4: 1.4-fold (0.15 log units) below; measured number inside the range.
By their numbers in this assay, from the lowest: compound 1; then compound 3; then compound 2; then compound 4.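

In this assay, for the compounds shown here, replacing phenyl with carboxy on the saturated chain carbon bound to a sulfur gives a 2.1-fold higher number from compound 2 to compound 4 (0.33 log units; beyond the scatter), the first step here that isolates a single change in one place. At this position, the six-membered aromatic ring can therefore give way to a carboxy group with only a modest change in the number. No available data explain this step. The compounds shown leave open how an amide, a methyl ester or a longer chain carrying the carboxy would compare at this place.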